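Cyclohexylcarbamoyl in place of pyrrolidin-1-yl: compound 3

The compounds below may be only part of what the source reports. "The series", "measured", "known", "first", "only" and "open" are said of these compounds alone.

Compound 1, `COc1ccc(/C(=C(/CCNC(=O)NCc2ccccc2)c2ccccc2)c2ccccc2)cc1`, in a functional assay on MDA-MB-231 cells (Homo sapiens) for cytotoxicity, read by MTT assay, with a stated time of 72 h; on this read-out higher numbers stand for weaker inhibition and lower numbers for stronger inhibition: > 50000 nM
Compound 2, `COc1ccc(/C(=C(/CCNC(=O)N2CCCC2)c2ccccc2)c2ccccc2)cc1`, in this assay: > 50000 nM

The two measured compounds share one core and differ only at the group on the carbonyl carbon. In this assay compound 1 gives > 50000 nM, which is a limit of the assay and not a number. Compound 2 gives > 50000 nM, again a limit rather than a number. The step that the two limits leave unreadable from compound 1 to compound 2 therefore cannot be sized, because both values sit at the limit of > 50000 nM in this assay, at which 2 of the 2 values shown sit. Compound 2 thus stands at the limit, with nothing in the numbers to set it apart from compound 1.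

Compound 3, `COc1ccc(/C(=C(/CCNC(=O)C(=O)NC2CCCCC2)c2ccccc2)c2ccccc2)cc1`, departs from compound 2 by cyclohexylcarbamoyl in place of pyrrolidin-1-yl on a carbonyl carbon. Among the measured compounds shown here, no measured step bears on this change with a readable size; the only step available is unreadable. On that basis compound 3 is expected to stay at the limit as well, and the step of a number no higher from compound 2 to compound 3 (the limit leaves the size open) is expected to be none beyond the scatter. The estimate for compound 3 in this assay is 50000 nM, with a range from 15000 nM to 100000 nM.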

Compound 3, half-maximal inhibitory concentration: 12200 nM
Estimate against measurement, compound 3: 4.1-fold (0.61 log units) above; the whole stated range lies above it.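

In this assay, the group on a carbonyl carbon whose other neighbour is an amide-type nitrogen proves able to move the read-out: cyclohexylcarbamoyl in place of pyrrolidin-1-yl gives an at least 4.0-fold lower number from compound 2 to compound 3 (0.61 log units; beyond the scatter), and cyclohexylcarbamoyl in place of benzylamino gives an at least 4.0-fold lower number from compound 1 to compound 3 (0.61 log units; beyond the scatter). Compound 3 is therefore the only compound shown with a readable value, whereas the earlier exchange of benzylamino for pyrrolidin-1-yl cannot be read. Both new steps give only a least size and not a full one, because compound 1 and compound 2 carry limits rather than numbers: the limit of > 50000 nM in this assay, at which 2 of the 3 values shown sit.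

The compounds shown leave open which part of cyclohexylcarbamoyl goes with the lower number, as its carbonyl, its amide hydrogen and its six-membered carbon ring all enter together in compound 3. They also leave open whether a phenylcarbamoyl group, a morpholin-4-yl group or a carboxylic acid on the same carbonyl carbon would give a readable value in this assay, and how such a value would compare with that of compound 3.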